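This account rests on a few compounds, and the source may have more. Where it says the series, first, only, none or still open, it means among the compounds named here.

Measured so far:
compound 1, `CNC1=CC(=O)c2c(cnc(C)c2C)C1=O` — 32600 nM
compound 2, `CNC1=CC(=O)c2cc(C)ncc2C1=O` — 6040 nM

Of the compounds shown here, two have been measured in a functional assay on PC-3M cells (Homo sapiens) for cytotoxicity, read by propidium iodide staining, with a stated time of 4 days; a lower number here means a stronger inhibitor, a higher number a weaker inhibitor. Compound 1 has the structure `CNC1=CC(=O)c2c(cnc(C)c2C)C1=O` and in this assay compound 1 gives 32600 nM. Compound 2, with the structure `CNC1=CC(=O)c2cc(C)ncc2C1=O`, gives in this assay a value of 6040 nM. Between the two, the step of a 5.4-fold lower number from compound 1 to compound 2 (0.73 log units; beyond the scatter) was the only change, and it put compound 2 at the lower of the two numbers, with compound 1 as its nearest neighbour.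

Compound 3, with the structure `Cc1cc2c(cn1)C(=O)C(NCl)=CC2=O`, has not yet been measured in this assay. It differs from compound 2 in one place: chloro in place of methyl on an amine nitrogen. Among the measured compounds shown here, the single measured step, a 5.4-fold lower number from compound 1 to compound 2 (0.73 log units; beyond the scatter), concerned a methyl on an aromatic carbon, not the amine nitrogen, so it bears on this change only indirectly and gives no direct guide to its size or direction. In the absence of a comparable step, no change beyond the scatter is expected in this assay, though the range must be wide. Compound 3 is therefore estimated to give 8000 nM in this assay, between 2500 nM and 30000 nM, a step of a 1.3-fold higher number from compound 2 to compound 3 (0.12 log units; within the scatter) from compound 2.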

Compound 3, half-maximal inhibitory concentration: 3230 nM
Compound 3: the middle estimate sits 2.5-fold (0.39 log units) above what was measured, and the stated range covers the measured number.
By their numbers in this assay, from the lowest: compounds 3 and 2 (each within the scatter of the next); then compound 1.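

In this assay, among the compounds shown here, chloro in place of methyl on the amine nitrogen gives a 1.9-fold lower number from compound 2 to compound 3 (0.27 log units; within the scatter) and so stays within the scatter, the first reading at this position of the shared core. The earlier step of a 5.4-fold lower number from compound 1 to compound 2 (0.73 log units; beyond the scatter) lay beyond the scatter but concerned a methyl on an aromatic carbon, so it said nothing about the amine nitrogen; this result shows that, for these two groups at least, the exchange on that nitrogen leaves the number indistinguishable from that of compound 2 in this cytotoxicity read-out. For the compounds shown here, nothing on hand accounts for this result, and the single pair cannot show how far the position tolerates change in general.

The compounds shown leave open how a longer chain such as propyl, a hydroxyl or a bare hydrogen would read on this amine nitrogen in this assay and whether any of them would move the number beyond the scatter. Also open, going by these compounds, is whether chloro in place of methyl on the amine nitrogen would read the same on the core of compound 1, which carries an extra methyl on an aromatic carbon.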